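Swapping vinyl for 4-bromophenyl on a carbonyl carbon

The source may hold more compounds than are shown below. What is called first, only, known or untested is meant among the compounds shown, and "the series" means these compounds.

- compound 1 `COc1ccc(/C=C/C(=O)c2ccc(OC)c3c2OC(C)(C)C=C3)cc1O` gives 800 nM
- compound 2 `C=CCOc1cc(/C=C/C(=O)c2ccc(OC)c3c2OC(C)(C)C=C3)ccc1OC` gives > 10000 nM (a limit of the assay, not a number)
- compound 3 `C=CC(=O)Oc1cc(/C=C/C(=O)c2ccc(OC)c3c2OC(C)(C)C=C3)ccc1OC` gives 390 nM

In a functional assay on A-375 cells (Homo sapiens) for cytotoxicity, read by MTT assay (a lower number here means a stronger inhibitor, a higher number a weaker inhibitor), compound 3 has the lower of the two exact numbers. Compound 4 `COc1ccc(/C=C/C(=O)c2ccc(OC)c3c2OC(C)(C)C=C3)cc1OC(=O)c1ccc(Br)cc1` differs from it by 4-bromophenyl in place of vinyl on a carbonyl carbon. Two kinds of measured step bear on this. Adding vinylcarbonyl to the oxygen was modest (a 2.1-fold lower number from compound 1 to compound 3 (0.31 log units; beyond the scatter)), whereas adding allyl there was large (an at least 12-fold higher number from compound 1 to compound 2 (1.09 log units; beyond the scatter)), as was the swap between them (an at least 25-fold lower number from compound 2 to compound 3 (1.40 log units; beyond the scatter)). Compound 4 keeps the carbonyl of compound 3, so a moderate step is expected in this assay rather than a large one. The expected step, toward a weaker inhibitor, is a 2.3-fold higher number from compound 3 to compound 4 (0.36 log units; beyond the scatter). The estimate for compound 4 is 900 nM, within an expected range from 200 nM to 5000 nM.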

Compound 4, half-maximal inhibitory concentration: 420 nM
Estimate against measurement, compound 4: 2.1-fold (0.33 log units) above, and the stated range covers the measured number.
By their numbers in this assay, from the lowest: compounds 3, 4 and 1 (each within the scatter of the next, the first and the last beyond it). At a limit, above all of these: compound 2.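

In this assay, 4-bromophenyl and vinyl on this carbonyl carbon cannot be told apart, so a much larger group with an aromatic ring is accepted here: a 1.1-fold higher number from compound 3 to compound 4 (0.03 log units; within the scatter). With hydrogen on the oxygen instead of the whole (4-bromophenyl)carbonyl group, the gap also stays within the scatter: a 1.9-fold lower number from compound 1 to compound 4 (0.28 log units; within the scatter). Compound 2 stands at a limit of the assay, not a number, and the step from it is an at least 23-fold lower number from compound 2 to compound 4 (1.37 log units; beyond the scatter). Still open, on these data alone, is whether the bromine matters, which a plain phenyl would test. An aminomethyl group on this carbonyl carbon is also untested among these compounds.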